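Urea and amide series on Daoy cells: no measurable potency

A few compounds are considered here, and "the series" means these few. Any claim that something is new, unique, unknown or untested is made for them only; others in the source may bear on it.

Of the compounds shown here, three have been measured in a functional assay on Daoy cells (Homo sapiens) for cytotoxicity, read by MTT assay, with a stated time of 72 h; on this read-out lower numbers stand for stronger inhibition and higher numbers for weaker inhibition. Compound 1 `COc1ccc(N(C)C(=O)N(C)c2cc(OC)c(OC)c(OC)c2)cc1` gives a value that is a limit of the assay, >= 125000 nM. Compound 2 `COc1cc(N(C)C(=O)N(C)c2ccc([N+](=O)[O-])cc2)cc(OC)c1OC` also gives only a limit in this assay, >= 125000 nM. Compound 3 `COc1cc(N(C)C(=O)c2ccc([N+](=O)[O-])cc2)cc(OC)c1OC` likewise sits at a limit in this assay, >= 125000 nM. All three therefore share (the limit of >= 125000 nM in this assay, at which 3 of the 3 values shown sit), and no numbered potency is available anywhere in the set.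

The change from compound 2 to compound 1 is methoxy in place of nitro on an aromatic carbon; the step it made, a step that the two limits leave unreadable from compound 2 to compound 1, cannot be sized because both ends are limits. Compound 4 `COc1ccc(C(=O)N(C)c2cc(OC)c(OC)c(OC)c2)cc1` is not yet measured; it differs from compound 3 by methoxy in place of nitro on an aromatic carbon, the same change at the same kind of place. The difference between the core of compound 3 and the core of compound 2 is not broken down here.

Because compound 3 stands at >= 125000 nM, and because the same change left compound 1 at >= 125000 nM, compound 4 is expected to remain at or near the limit in this assay, with an expected step of a number no higher from compound 3 to compound 4 (the limit leaves the size open). The estimate for compound 4 is 125000 nM, expected to fall between 60000 nM and 300000 nM.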

Compound 4, half-maximal inhibitory concentration: >= 125000 nM
Compound 4 ended at the assay's limit; the forecaster's own chance of this, stated with the estimate: 80%; the middle value lies on the limit itself.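

Compound 3 and compound 4 both give only a limit in this assay, so no step can be read between them, and the set remains without a numbered potency: the limit of >= 125000 nM in this assay, at which 4 of the 4 values shown sit.

The compounds shown leave open whether methoxy in place of nitro on an aromatic carbon changes potency at all, and whether any urea or amide here has a measurable potency in this assay.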